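Ester in place of the amide at the carbonyl

The compounds below may be only part of what the source reports. "The series", "measured", "known", "first", "only" and "open" are said of these compounds alone.

Within the shared core of compound 1 `CC[C@@H](C)[C@H](NC(=O)c1ccc(C(CC)(CC)c2ccc(OCC(=O)C(C)(C)C)c(C)c2)n1CC)C(=O)OC`, the group on the carbonyl sets the numbers in an assay on HL-60 cells for agonist activity at vitamin D3 receptor (Homo sapiens), read by microscopy, with a stated time of 96 h; a lower number here means that less compound is needed, a higher number that more compound is needed for the effect. Compound 2 `CCn1c(C(=O)NCCN(C)C)ccc1C(CC)(CC)c1ccc(OCC(=O)C(C)(C)C)c(C)c1` gives 77 nM, compound 1 gives 590 nM, and compound 3 `CCn1c(C(=O)N(C)CC(=O)O)ccc1C(CC)(CC)c1ccc(OCC(=O)C(C)(C)C)c(C)c1` gives 1390 nM, the highest of the three: an 18-fold higher number from compound 2 to compound 3 (1.26 log units; beyond the scatter) and a 2.4-fold higher number from compound 1 to compound 3 (0.37 log units; beyond the scatter). Compound 4 `CCOC(=O)c1ccc(OC(=O)c2ccc(C(CC)(CC)c3ccc(OCC(=O)C(C)(C)C)c(C)c3)n2CC)cc1` carries 4-(ethoxycarbonyl)phenoxy in place of (carboxymethyl)(methyl)amino on a carbonyl carbon. Going by the values given here, no measured step exchanges the amide for an ester, so only the two steps into compound 3 bear on this one, and both ran upward when (carboxymethyl)(methyl)amino entered. For compound 4 the step is expected to run downward, a 2.8-fold lower number from compound 3 to compound 4 (0.44 log units; beyond the scatter). Compound 4 is estimated at 500 nM, within 100 nM to 2500 nM.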

Compound 4, half-maximal effective concentration: 45600 nM
Beside the measured number, compound 4's estimate is 91-fold (1.96 log units) below it; measured number above the stated range.
By their numbers in this assay, from the lowest: compound 2; then compound 1; then compound 3; then compound 4.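

In this assay, compound 4 stands apart from all three nitrogen-linked compounds: a 33-fold higher number from compound 3 to compound 4 (1.52 log units; beyond the scatter) and a 590-fold higher number from compound 2 to compound 4 (2.77 log units; beyond the scatter) and a 77-fold higher number from compound 1 to compound 4 (1.89 log units; beyond the scatter) are all large rises. Even the smallest of these exceeds the whole spread among the amides, an 18-fold higher number from compound 2 to compound 3 (1.26 log units; beyond the scatter), so the carbonyl position is far less forgiving of this change than the amide variations suggested. No available data explain the rise.

The 4-(ethoxycarbonyl)phenoxy group changes both the linking atom and the attached group, so their contributions remain unseparated. An anilide bearing the same ethoxycarbonyl group, or a simple methyl ester on the carbonyl, would separate them.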